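Extending the chain further in the chloromethyl ketone series

This account rests on a few compounds, and the source may have more. Where it says the series, first, only, none or still open, it means among the compounds named here.

Compound 3 `CCCCCCCCCCCCCCCCSC[C@H](NC(C)=O)C(=O)CCl` is the weakest of the two numbers in a functional assay on NALM-6 cells (Homo sapiens) (a lower number here means a stronger inhibitor, a higher number a weaker inhibitor), where compound 3 gives 16000 nM. Its nearest neighbour is compound 2 `CCCCCCCCCCCCCCSC[C@H](NC(C)=O)C(=O)CCl`, for which compound 2 gives 8700 nM; a 1.8-fold higher number from compound 2 to compound 3 (0.26 log units; within the scatter). Compound 1 `CCCCCCCCCCCCCSC[C@H](NC(C)=O)C(=O)CCl` reaches only a limit of the assay, and compound 1 gives > 100000 nM. Compound 4 `CCCCCCCCCCCCCCCCCCSC[C@H](NC(C)=O)C(=O)CCl` differs from compound 3 by ethyl in place of hydrogen on a saturated chain carbon, ten or more bonds along the chain from a sulfur. The relevant steps are an at least 11-fold lower number from compound 1 to compound 2 (1.06 log units; beyond the scatter) and an at least 6.2-fold lower number from compound 1 to compound 3 (0.79 log units; beyond the scatter), both starting from the limit (the limit of > 100000 nM in this assay, at which 1 of the 3 values shown sits), while the step between the two numbered compounds, a 1.8-fold higher number from compound 2 to compound 3 (0.26 log units; within the scatter), stays within the scatter. Compound 4 is therefore expected to show a 1.6-fold higher number from compound 3 to compound 4 (0.19 log units; within the scatter), a step within the scatter. Compound 4 is estimated at 25000 nM, between 8000 nM and 80000 nM.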

Compound 4, half-maximal inhibitory concentration: > 100000 nM
Compound 4: only a limit was reported; the forecaster's own chance of this, stated with the estimate: 12%; at least 4.0-fold (0.60 log units) between middle value and limit.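

In this assay, the ethyl change that extends the chain of compound 3 now has a clear effect, an at least 6.2-fold higher number from compound 3 to compound 4 (0.79 log units; beyond the scatter), and the full butyl extension gives an at least 11-fold higher number from compound 2 to compound 4 (1.06 log units; beyond the scatter). Among these four compounds, readable numbers therefore occur only for compound 2 and compound 3, with a limit on either side of them at compound 1 and compound 4. The step between compound 1 and compound 4 cannot be read, since both values are limits: the limit of > 100000 nM in this assay, at which 2 of the 4 values shown sit.

As far as these compounds go, how far compound 4 lies past its limit remains open. Also open, from the compounds shown here alone, is whether an amine or a carboxylic acid at the far end of its chain would restore a readable number.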